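Swapping the aryl imine substituent in a thienyl-benzothiazole series

The source may report more compounds than this note shows. Statements on the series, on what has been measured and on what is new or still open speak of the compounds shown alone.

Of the compounds shown here, three of a shared core have been measured in an ADME assay on cells (Rhabdomyosarcoma cell, Homo sapiens) for cytotoxicity, read by MTT assay, with a stated time of 72 h; on this read-out lower numbers stand for higher toxicity in this test and higher numbers for lower toxicity in this test. Compound 1 `Nc1sc2c(c1-c1nc3ccccc3s1)CCCC2` gives 253 ug/mL, compound 2 `Nc1sc2c(c1-c1nc3cc(Cl)ccc3s1)CCC2` gives 59.1 ug/mL, and compound 3 `Fc1ccc(/C=N/c2sc3c(c2-c2nc4ccccc4s2)CCC3)cc1` gives 290 ug/mL. Compound 3 thus carries the highest of the three numbers, but compound 1 sits so close that the two cannot be told apart within the usual scatter, whereas compound 2 lies clearly lower, beyond the scatter.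

Compound 4 `Clc1ccccc1/C=N/c1sc2c(c1-c1nc3ccccc3s1)CCC2` has not yet been measured in this assay. It differs from compound 3 by 2-chlorophenyl in place of 4-fluorophenyl on a carbon with a double bond to nitrogen. Among the measured compounds shown here, no measured pair shows the effect of such an exchange of the aryl group on the imine, so there is no step to lean on. Both groups are halogenated phenyl rings of the same size, and compound 3 already sits at the top of the range. The expected step from compound 3 to compound 4 is therefore small, a 1.2-fold lower number from compound 3 to compound 4 (0.08 log units; within the scatter), with no direction beyond the scatter. Compound 4 is estimated at 240 ug/mL, expected to fall between 120 ug/mL and 480 ug/mL.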

Compound 4, half-maximal cytotoxic concentration: 123 ug/mL
Compound 4: middle estimate off by 2.0-fold (0.29 log units), on the high side; low and high end bracket the measured number.
By their numbers in this assay, from the lowest: compound 2; then compound 4; then compounds 1 and 3 (each within the scatter of the next).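

In this assay, among the compounds shown here, the exchange of 4-fluorophenyl for 2-chlorophenyl on a carbon with a double bond to nitrogen gives a 2.4-fold lower number from compound 3 to compound 4 (0.37 log units; beyond the scatter) and is the first single change in this set that can be read. It shows that this position is not indifferent to the aryl group it carries: two halogenated phenyl rings, neither with a hydrogen-bond donor or acceptor, still separate beyond the scatter, although the step is modest. Nothing at hand accounts for the difference.

The two rings differ in both the halogen and its place on the ring, and the compounds shown leave open which of these carries the step. Also open, on these data alone, is how a plain phenyl or a pyridine ring would read on the same carbon.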